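The source may report more compounds than this note shows. Statements on the series, on what has been measured and on what is new or still open speak of the compounds shown alone.

The study moves from compound 2, `CCC(=O)NCCCc1cccc(F)c1`, to compound 3, `CCCC(=O)NCCCc1cccc(F)c1`, within a series that also holds compound 1, `CCCC(=O)NCCCc1cccc(OC)c1`. In an assay for binding affinity to melatonin receptor (Gallus gallus) (on this read-out lower numbers stand for stronger inhibition and higher numbers for weaker inhibition), compound 1 gives 5.5 nM, while compound 2 gives 740 nM, the highest of the two numbers and a gap beyond the scatter; the two structures differ in more than one place, so the values alone are compared. The change from compound 2 to compound 3 is methyl in place of hydrogen on a saturated chain carbon, two bonds along the chain from a carbonyl carbon. In this assay a moderate fall in the number is expected for compound 3, since compound 1, carrying the same chain length, gives 5.5 nM. Compound 3 is therefore estimated at 120 nM, between 25 nM and 500 nM, an expected step of a 6.2-fold lower number from compound 2 to compound 3 (0.79 log units; beyond the scatter).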

Compound 3, inhibition constant: 434 nM
Compound 3: the middle estimate sits 3.6-fold (0.56 log units) below what was measured, within the range that was stated.
By their numbers in this assay, from the lowest: compound 1; then compounds 3 and 2 (each within the scatter of the next).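

In this assay, methyl in place of hydrogen on a saturated chain carbon, two bonds along the chain from a carbonyl carbon, gives a 1.7-fold lower number from compound 2 to compound 3 (0.23 log units; within the scatter) with fluoro on the aromatic carbon, a step that cannot be told from scatter. Fluoro in place of methoxy on an aromatic carbon gives a 79-fold higher number from compound 1 to compound 3 (1.90 log units; beyond the scatter) and is the large step here. No evidence is at hand to explain either step. Going by these compounds, whether the methyl step reads the same with methoxy on the aromatic carbon stays open. So does the effect of a longer chain on the carbonyl, or of a hydroxyl or an amine on that aromatic carbon.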